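The source may report more compounds than this note shows. Statements on the series, on what has been measured and on what is new or still open speak of the compounds shown alone.

Compound 1, `COc1cc(-c2nnc3n2NC(c2ccco2)C(C(=O)c2ccc(Br)cc2)S3)cc(OC)c1OC`, gives 42100 nM in a functional assay on A549 cells (Homo sapiens) for cytotoxicity, read by MTT assay, with a stated time of 48 h; on this read-out higher numbers stand for weaker inhibition and lower numbers for stronger inhibition.
Compound 2, `COc1cc(-c2nnc3n2NC(c2ccco2)C(C(=O)c2ccc(O)cc2)S3)cc(OC)c1OC`, gives 93400 nM in this assay.
Compound 3, `COc1cc(-c2nnc3n2NC(c2ccco2)C(C(=O)c2ccc([N+](=O)[O-])cc2)S3)cc(OC)c1OC`, gives only a limit of the assay in this assay, > 100000 nM.

Among the two numbers that are not limits, compound 1 stands lowest, with compound 2 nearest to it. Both measured steps start from compound 1 and change the group on the ring attached to the carbonyl: a 2.2-fold higher number from compound 1 to compound 2 (0.35 log units; beyond the scatter), and an at least 2.3-fold higher number from compound 1 to compound 3 (0.37 log units; beyond the scatter). Compound 3 sits at the limit of > 100000 nM in this assay, at which 1 of the 3 values shown sits. Each change away from bromo on that ring therefore gave a modestly higher number in this assay.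

Compound 4, `COc1cccc(C(=O)C2Sc3nnc(-c4cc(OC)c(OC)c(OC)c4)n3NC2c2ccco2)c1`, is not yet measured. It differs from compound 1 in 3-methoxyphenyl in place of 4-bromophenyl on a carbonyl carbon. Neither measured step places a methoxy on that ring, so the two steps from compound 1 only show that replacing bromo there has so far weakened inhibition modestly. Compound 4 is therefore expected to give a somewhat higher number than compound 1, a 1.5-fold higher number from compound 1 to compound 4 (0.19 log units; within the scatter). The estimate for compound 4 in this assay is 65000 nM, between 25000 nM and 160000 nM.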

Compound 4, half-maximal inhibitory concentration: > 100000 nM
Compound 4: a limit, no number; the forecaster's own chance of this, stated with the estimate: 30%; middle value at least 1.5-fold (0.18 log units) from the limit.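

The change to 3-methoxyphenyl in place of 4-bromophenyl on a carbonyl carbon gives an at least 2.3-fold higher number from compound 1 to compound 4 (0.37 log units; beyond the scatter), so a third replacement of that group, and the first to carry a methoxy, also weakens inhibition in this assay. The other step that can be read, an at least 1.0-fold higher number from compound 2 to compound 4 (0.02 log units; that floor lies within the scatter), separates nothing. The value of compound 4 is a limit of the assay, as is that of compound 3, and the step between them cannot be read: the limit of > 100000 nM in this assay, at which 2 of the 4 values shown sit.

From the compounds shown here alone, it remains open whether chloro or fluoro in place of bromo would keep the number of compound 1, or whether an amine there would move it in either direction. Going by these compounds, it is also open whether 4-methoxyphenyl would read differently from 3-methoxyphenyl on that carbonyl carbon.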